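A few compounds are considered here, and "the series" means these few. Any claim that something is new, unique, unknown or untested is made for them only; others in the source may bear on it.

Compound 1 `COc1cc(-c2cc(/C=C/C(=O)c3ccc(Cl)c(Cl)c3)[nH]n2)cc(OC)c1OC` is the weakest of the three compounds measured in a functional assay on 786-0 cells (Homo sapiens) for inhibition, read by sulforhodamine B assay, with a stated time of 48 h (on this read-out lower numbers stand for stronger inhibition of growth and higher numbers for weaker inhibition of growth), where compound 1 gives 68000 nM. Compound 2 `COc1ccc(-c2cc(/C=C/C(=O)c3cc(OC)c(OC)c(OC)c3)[nH]n2)cc1OC` gives 2900 nM in this assay, and compound 3 `COc1ccc(-c2cc(/C=C/C(=O)c3ccc(N)cc3)[nH]n2)cc1` gives 5690 nM. Both gaps from compound 1 lie beyond the usual scatter: the nearest number, that of compound 3, is well below it, and that of compound 2 lies further still. All three share the same core, a pyrazole carrying an aryl group on one side and an unsaturated ketone on the other, and they differ in the aryl groups at the two ends.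

Compound 4 `COc1ccc(C(=O)/C=C/c2cc(-c3cc(OC)c(OC)c(OC)c3)n[nH]2)cc1OC` is derived from compound 1 by a single exchange on the ketone end: 3,4-dimethoxyphenyl in place of 3,4-dichlorophenyl on a carbonyl carbon. Among the compounds with values here, no pair of measured compounds shows this exact exchange. Still, the two compounds that carry oxygen-bearing aryl groups on the carbonyl carbon, compound 2 and compound 3 with its amine-bearing aryl, both give far lower numbers than compound 1, so the step from compound 1 to compound 4 is expected to be a sizeable fall in this assay, a 17-fold lower number from compound 1 to compound 4 (1.23 log units; beyond the scatter), rather than a change within the scatter. Compound 4 is accordingly estimated at 4000 nM, with a likely range from 1500 nM to 12000 nM.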

Compound 4, concentration for total growth inhibition: 2860 nM
Beside the measured number, compound 4's estimate is 1.4-fold (0.15 log units) above it, within the range that was stated.
By their numbers in this assay, from the lowest: compounds 4, 2 and 3 (each within the scatter of the next); then compound 1.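

Within the data shown here, the exchange of 3,4-dichlorophenyl for 3,4-dimethoxyphenyl on a carbonyl carbon gives the first direct reading of this position: in this assay the step is a 24-fold lower number from compound 1 to compound 4 (1.38 log units; beyond the scatter), which is large and lies beyond the scatter. The earlier compounds shown here differ from one another in more than one place, so they could not show what the group on the carbonyl carbon does alone; this pair shows that this single exchange, with the rest of the molecule unchanged, is enough to produce a large fall in the number. No measurement at hand bears on the cause of this step.

From the compounds shown here alone, it remains open whether the fall follows from the arrival of the two methoxy groups or from the departure of the two chlorine atoms, and whether an unsubstituted phenyl, a 4-methoxyphenyl, a 3,4-dihydroxyphenyl or a 4-aminophenyl on the same carbonyl carbon would give a similar number. Also open, going by these compounds, is whether this exchange would produce a step of similar size in compounds that carry a different aryl group elsewhere on the shared core.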